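Amide substituent changes on the shared core, paw edema series

This account rests on a few compounds, and the source may have more. Where it says the series, first, only, none or still open, it means among the compounds named here.

Compound 3 `COc1ccc(-n2nc(C(=O)Nc3ccc(C(F)(F)F)cc3)nc2-c2cc(OC)c(OC)c(OC)c2)cc1` is tested in a functional assay on the whole organism for inhibition, with Rattus norvegicus as the target, read by paw edema, with stated times of 30 min and 5 h, at a dose of 0.28 mmol/kg by the oral route (a lower number here means less inhibition, a higher number more inhibition at the dose given (going by the name of the read-out)), and gives 50%. On the numbers in hand it stands level with compound 1 `CNC(=O)c1nc(-c2cc(OC)c(OC)c(OC)c2)n(-c2ccc(OC)cc2)n1`, which in this assay gives 50%, the two together being the lowest of the three values; compound 2 `COc1ccc(NC(=O)c2nc(-c3cc(OC)c(OC)c(OC)c3)n(-c3ccc(OC)cc3)n2)cc1` gives 51% in this assay and sits furthest from compound 3. All steps among these three stay within the scatter: a number 1 percentage points higher from compound 1 to compound 2 (within the scatter), no change at the digits printed from compound 1 to compound 3 (within the scatter), and a number 1 percentage points lower from compound 2 to compound 3 (within the scatter). Compound 4 `COc1ccc(-n2nc(C(=O)Nc3ccc(O)cc3)nc2-c2cc(OC)c(OC)c(OC)c2)cc1` differs from compound 3 by hydroxy in place of trifluoromethyl on an aromatic carbon. The step that bears most directly on this is the exchange of substituents on the same aromatic carbon, a number 1 percentage points lower from compound 2 to compound 3 (within the scatter), and the two amide-nitrogen replacements from compound 1 likewise moved nothing beyond the scatter. On that basis no step beyond the scatter is expected, no change at the digits printed from compound 3 to compound 4 (within the scatter). Compound 4 is therefore expected to give about 50% in this assay, estimated between 38% and 62%.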

Compound 4, a percentage reported as inhibition, in the whole organism at one dose (the size of the read-out at that dose, not a potency): 27%
The estimate for compound 4 lay 23 percentage points above the measured number; the whole stated range lies above it.
By their numbers in this assay, from the lowest: compound 4; then compounds 1, 3 and 2 (each within the scatter of the next).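

In this assay the amide substituent proves not to be indifferent: 4-hydroxyphenyl in place of methyl gives a number 23 percentage points lower from compound 1 to compound 4 (beyond the scatter) and hydroxy in place of trifluoromethyl gives a number 23 percentage points lower from compound 3 to compound 4 (beyond the scatter) while the three earlier amide substituents stayed within the scatter of one another. Hydrogen in place of methyl on the oxygen alone gives a number 24 percentage points lower from compound 2 to compound 4 (beyond the scatter) so the drop goes with the free hydroxy in this series and not with a substituted phenyl on the amide nitrogen as such. Nothing at hand accounts for this drop.

As far as these compounds go, whether the drop is specific to hydroxy stays open, since an amine or a carboxylic acid in its place could read either way. Also open, from the compounds shown here alone, is whether the drop would hold on another amide-linked ring or at another dose.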